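The source may report more compounds than this note shows. Statements on the series, on what has been measured and on what is new or still open speak of the compounds shown alone.

In an ADME assay on HEK-293T cells (Homo sapiens) for cytotoxicity, read by MTT assay, with a stated time of 24 h (on this read-out higher numbers stand for lower toxicity in this test and lower numbers for higher toxicity in this test), compound 1 `Cc1ccc(-c2nn(-c3ccccc3)cc2-c2nc3ccccc3n2S(=O)(=O)c2ccc(C(F)(F)F)cc2)cc1` gives 182000 nM and compound 2 `Cc1ccc(C)c(S(=O)(=O)n2c(-c3cn(-c4ccccc4)nc3-c3ccc(C(F)(F)F)cc3)nc3ccccc32)c1` gives 223000 nM while compound 3 `O=S(=O)(c1ccc(Cl)cc1)n1c(-c2cn(-c3ccccc3)nc2-c2ccc(C(F)(F)F)cc2)nc2ccccc21` gives 75300 nM as the lowest of the three numbers. Compound 4 `O=S(=O)(c1ccc(C(F)(F)F)cc1)n1c(-c2cn(-c3ccccc3)nc2-c2ccc(C(F)(F)F)cc2)nc2ccccc21` differs from compound 3 by one change (trifluoromethyl in place of chloro on an aromatic carbon) with trifluoromethyl in place of chloro on an aromatic carbon. Among the measured compounds shown here, the only measured step bearing on it exchanges the aryl group on the sulfonyl sulfur: a 3.0-fold lower number from compound 2 to compound 3 (0.47 log units; beyond the scatter) is modest and beyond the scatter. Compound 1 carries 4-(trifluoromethyl)phenyl there but differs elsewhere as well. For the measured compounds named here, no measured step makes this exact exchange, so a small upward move within the scatter is expected in this assay with a 1.3-fold higher number from compound 3 to compound 4 (0.12 log units; within the scatter) as the estimated step. Compound 4 is estimated at 100000 nM with an expected range from 50000 nM to 200000 nM in this series.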

Compound 4, half-maximal cytotoxic concentration: 63200 nM
The estimate for compound 4 lay 1.6-fold (0.20 log units) above the measured number; measured number inside the range.
By their numbers in this assay, from the lowest: compounds 4 and 3 (each within the scatter of the next); then compounds 1 and 2 (each within the scatter of the next).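

In this assay, a 1.2-fold lower number from compound 3 to compound 4 (0.08 log units; within the scatter), so chloro and trifluoromethyl on this sulfonyl aryl ring cannot be told apart. Larger moves appear elsewhere: a 3.5-fold lower number from compound 2 to compound 4 (0.55 log units; beyond the scatter) on exchange of the whole sulfonyl aryl group, and a 2.9-fold lower number from compound 1 to compound 4 (0.46 log units; beyond the scatter) at a second aromatic site outside that group. No measurement shown gives a cause for any of these steps. Open, going by these compounds, is how an amine or a carboxylic acid would read on the sulfonyl aryl ring. Also open, on these data alone, is whether the methyl to trifluoromethyl step holds with other sulfonyl aryl groups.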